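The source may hold more compounds than are shown below. What is called first, only, known or untested is meant among the compounds shown, and "the series" means these compounds.

Compound 1 `COc1cc(NCc2ccc(Cl)cc2)cc(OC)c1OC`: > 80000 nM (a limit)
Compound 2 `COc1ccc(CNc2cc(OC)c(OC)c(OC)c2)cc1Br`: 29400 nM
Compound 3 `CCC/C=C/C(=O)N(Cc1ccc(OC)c(O)c1)c1cc(OC)c(OC)c(OC)c1`: 70 nM

All three results come from a functional assay on MGC-803 cells (Homo sapiens) for inhibition, read by MTT assay, with a stated time of 48 h; on this read-out lower numbers stand for stronger inhibition and higher numbers for weaker inhibition. Compound 1 gives no exact number: its result is the limit of > 80000 nM in this assay, at which 1 of the 3 values shown sits. Compound 2 gives 29400 nM, and compound 3 gives 70 nM, a much lower number and so a much stronger inhibition.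

The next compound to be tested is compound 4 `COc1cc(NCc2ccc(C)cc2)cc(OC)c1OC`. It differs from compound 1 in one place, with methyl in place of chloro on an aromatic carbon, so that 4-chlorophenyl becomes 4-methylphenyl: methyl in place of chloro on an aromatic carbon.

Within the data shown here, no measured pair of compounds shows what this kind of swap does in this assay, so any forecast is rough. The change is small, and only a small step is expected, with no firm direction. Compound 3 resembles compound 1 less closely than compound 2 does, so the best guide is compound 2, which gives 29400 nM. Compound 4 is therefore expected to stay in the same poorly active range and could again return only a limit.

The expected change is modest: an at least 1.3-fold lower number from compound 1 to compound 4 (0.12 log units; that floor lies within the scatter). Compound 4 is estimated at 60000 nM, with an expected range from 20000 nM to 120000 nM.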

Compound 4, half-maximal inhibitory concentration: > 80000 nM
Compound 4: only a limit was reported (the forecaster's own chance of this, stated with the estimate: 50%); middle value at least 1.3-fold (0.12 log units) away from the limit.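

In this assay compound 4 gives > 80000 nM, a limit and not a number. Among these compounds, compound 1 also gives only a limit, so no step between compound 1 and compound 4 can be read: the limit of > 80000 nM in this assay, at which 2 of the 4 values shown sit. The compounds shown leave open whether 4-methylphenyl and 4-chlorophenyl differ at all in strength of inhibition.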